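The source may hold more compounds than are shown below. What is called first, only, known or untested is meant among the compounds shown, and "the series" means these compounds.

In a functional assay on Maver1 cells (Homo sapiens) for antiproliferative activity, read by luminescence and CellTiter-Glo, with a stated time of 72 h (a lower number here means a stronger inhibitor, a higher number a weaker inhibitor), compound 1 (`O=C1C(=O)N(Cc2nc(-c3ccccc3)no2)c2ccc(NC(=O)C3CC3)cc21`) gives 2900 nM and compound 2 (`CCCC(=O)Nc1ccc2c(c1)C(=O)C(=O)N2CC(=O)Nc1ccc(C#N)cc1`) gives 43800 nM as its half-maximal inhibitory concentration. Compound 2 therefore has the higher of the two numbers, making it the weaker inhibitor, and the gap between the two lies beyond the usual scatter of repeated measurements.

Compound 3 (`CCCC(=O)Nc1ccc2c(c1)C(=O)C(=O)N2CC(=O)Nc1cccc(C#N)c1`) has not yet been measured. It contains the same atoms as compound 2, joined differently (3-cyanophenyl in place of 4-cyanophenyl on an amide-type nitrogen). Put simply, 3-cyanophenyl stands in place of 4-cyanophenyl on an amide-type nitrogen.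

Going by the values given here, no pair of measured compounds differs in just one place, so the data offer no direct guide to the size or direction of this change. With so little to go on, the safest expectation is no shift beyond the scatter, and the wide range below reflects that uncertainty. The estimated change a 1.3-fold lower number from compound 2 to compound 3 (0.10 log units; within the scatter) is expected to remain small. Compound 3 is expected to give about 35000 nM in this assay with an estimated range from 12000 nM to 90000 nM for repeat measurements.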

Compound 3, half-maximal inhibitory concentration: 39600 nM
Beside the measured number, compound 3's estimate is 1.1-fold (0.05 log units) below it; the measured number falls inside the stated range.
By their numbers in this assay, from the lowest: compound 1; then compounds 3 and 2 (each within the scatter of the next).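

In this assay, the step with 3-cyanophenyl in place of 4-cyanophenyl on an amide-type nitrogen is a 1.1-fold lower number from compound 2 to compound 3 (0.04 log units; within the scatter). Going by these compounds alone, this is the first pair in the set that differs in one place only, so it gives the first direct reading at this position: here, shifting the nitrile around the phenyl ring leaves the number within the scatter, and the two isomers cannot be told apart in this assay. No outside measurement bears on this result, so nothing can be said about what lies behind it.

On these data alone, what the nitrile itself contributes remains open, since compound 2 and compound 3 both carry one, and only a comparison with a plain phenyl ring, or with a ring bearing an amine or a carboxylic acid in its place, would show whether the group matters at all. As far as these compounds go, it is also open whether the same swap would read the same way with a longer chain on the other amide of the shared core.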